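A few compounds are considered here, and "the series" means these few. Any claim that something is new, unique, unknown or untested is made for them only; others in the source may bear on it.

Measured compounds:
compound 1 `CCOC(=O)C1=C(C)NC(C)=C(C(=O)OCC)C1c1ccc(OCC(=O)NCc2ccccc2)cc1` — 31.1%
compound 2 `CCOC(=O)C1=C(C)NC(C)=C(C(=O)OCC)C1c1ccc(OCC(=O)NNC(=O)c2ccc(C)cc2)cc1` — 47.3%
compound 3 `CCOC(=O)C1=C(C)NC(C)=C(C(=O)OCC)C1c1ccc(OCC(=O)NNC(=O)c2sccc2Cl)cc1` — 56.3%

In a functional assay on the whole organism (strain Wistar) for inhibition, with Rattus norvegicus as the target, read by paw edema, with stated times of 30 min and 3 h, at a dose of 20 mg/kg (on this read-out lower numbers stand for less inhibition and higher numbers for more inhibition at the one dose given (going by the name of the read-out)), compound 3 has the highest of the three numbers; compound 2 lies a number 9 percentage points higher from compound 2 to compound 3 (within the scatter), while compound 1 lies well apart, a number 25.2 percentage points higher from compound 1 to compound 3 (beyond the scatter). The unmeasured compound 4 `CCOC(=O)C1=C(C)NC(C)=C(C(=O)OCC)C1c1ccc(OCC(=O)NN2C(=O)c3ccccc3C2=O)cc1` differs from compound 3 at the same amide-type nitrogen that varies across the series: a group of 11 heavy atoms (8 carbon, 1 nitrogen, 2 oxygen; one five-membered non-aromatic ring with 1 hetero atom, one six-membered aromatic ring of carbon only) in place of a group of 9 heavy atoms (5 carbon, 1 nitrogen, 1 oxygen, 1 sulfur, 1 chlorine; one five-membered aromatic ring with 1 hetero atom), on an amide-type nitrogen. Among the compounds with values here, two steps bear on this position, a number 16.2 percentage points higher from compound 1 to compound 2 (beyond the scatter) and a number 25.2 percentage points higher from compound 1 to compound 3 (beyond the scatter), both modest gains when the benzyl was replaced by a carbonyl-bearing amino group. Compound 4 keeps a carbonyl-bearing nitrogen there but loses the hydrogen-bond donor, so a step near zero or slightly downward is expected, a number 8.3 percentage points lower from compound 3 to compound 4 (within the scatter). Compound 4 is therefore estimated at 48%, within 34% to 62%.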

Compound 4, a percentage reported as inhibition, in the whole organism at one dose (the size of the read-out at that dose, not a potency): 59.3%
Estimate against measurement, compound 4: 11.3 percentage points below, within the range that was stated.
By their numbers in this assay, from the lowest: compound 1; then compounds 2, 3 and 4 (each within the scatter of the next, the first and the last beyond it).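

In this assay the step of a number 3 percentage points higher from compound 3 to compound 4 (within the scatter) shows that the ring-closed group, with 0 hydrogen-bond donors on the amide-type nitrogen, holds the level of the open acyl group of compound 3. The steps of a number 12 percentage points higher from compound 2 to compound 4 (beyond the scatter) and a number 28.2 percentage points higher from compound 1 to compound 4 (beyond the scatter) show that this position does not need that hydrogen-bond donor for the numbers seen here. Nothing measured here says why the numbers fall this way.

Still open, on these data alone, is how a plain amine on this nitrogen would compare. So is a longer chain ending in a carboxylic acid.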